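Amide variation on the shared core toward compound 4

The source may hold more compounds than are shown below. What is called first, only, known or untested is meant among the compounds shown, and "the series" means these compounds.

Going by the values given here, compound 2 `CC1CCC(C(=O)N2CC(c3nc(-c4cccc(Cl)c4)no3)C2)CC1` is one of three compounds so far measured in an assay on HEK293 cells for negative allosteric modulation of metabotropic glutamate receptor 5 (Homo sapiens), read by FLIPR; on this read-out lower numbers stand for stronger inhibition and higher numbers for weaker inhibition. In this assay compound 2 gives > 10000 nM, which is a limit of the assay and not a number. Compound 1 `O=C(C1CCC(F)(F)CC1)N1CC(c2nc(-c3cccc(F)c3)no2)C1` gives > 10000 nM in this assay, also a limit. Compound 3 `O=C(c1ccc(F)c(F)c1)N1CC(c2nc(-c3cccc(F)c3)no2)C1` gives > 10000 nM in this assay, again a limit. Among the compounds with values here, the only single-point step among the measured compounds, a step that the two limits leave unreadable from compound 1 to compound 3, cannot be read because both of its ends are limits; what the three values show is the limit of > 10000 nM in this assay, at which 3 of the 3 values shown sit. Compound 2 therefore stands where every measured compound stands, at the limit, with no ordering among them possible.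

Compound 4 `O=C(C1CCC1)N1CC(c2nc(-c3cccc(Cl)c3)no2)C1` differs from compound 2 by cyclobutyl in place of 4-methylcyclohexyl on a carbonyl carbon. Within the data shown here, the only measured step that touches the group on the carbonyl carbon is the one between compound 1 and compound 3, and its size is not readable, so no measured step gives a size for this change. With nothing beyond limits to lean on, the step from compound 2 to compound 4 is expected to be a number no higher from compound 2 to compound 4 (the limit leaves the size open), that is, no readable change. Compound 4 is accordingly estimated in this assay at 10000 nM, with a range from 2500 nM to 40000 nM, and most likely again reported only as a limit.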

Compound 4, half-maximal inhibitory concentration: 1500 nM
Beside the measured number, compound 4's estimate is 6.7-fold (0.82 log units) above it; measured number below the stated range.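

In this assay, going by these compounds alone, the group on the carbonyl carbon is the first place to give a readable step: cyclobutyl in place of 4-methylcyclohexyl gives an at least 6.6-fold lower number from compound 2 to compound 4 (0.82 log units; beyond the scatter), and this size is only a lower bound, since the value of compound 2 is a limit of the assay and not a number. The rest of the structure is the same in compound 2 and compound 4, so this one change on the carbonyl carbon is enough to bring a compound of this series to a measured number in this assay. Compound 4 alone stands off the limit: the limit of > 10000 nM in this assay, at which 3 of the 4 values shown sit.

The change from 4-methylcyclohexyl to cyclobutyl alters ring size, carbon count and the methyl group together, so the compounds shown cannot tell these apart, and the step that has limits at both ends cannot be read. From the compounds shown here alone, whether cyclopropyl, cyclopentyl, a branched chain such as isopropyl or a ring carrying an amine on the carbonyl carbon would give a lower or higher number than compound 4 remains open.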